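Amide ring closure and tolerance in liver cells

The compounds below may be only part of what the source reports. "The series", "measured", "known", "first", "only" and "open" are said of these compounds alone.

In an ADME assay on Huh-7 cells (Homo sapiens) for cytotoxicity, read by MTT assay, with a stated time of 72 h (a higher number here means that more compound is tolerated, a lower number that less compound is tolerated), compound 2 `CCN(CC)C(=O)c1sc2nc(-c3ccccc3)cc(C(F)(F)F)c2c1N` reaches only the limit > 100000 nM, so no number is known for it. Compound 1 `CCOC(=O)c1sc2nc(-c3ccccc3)cc(C(F)(F)F)c2c1N` likewise stands at a limit, > 20000 nM, in this assay. The step that the two limits leave unreadable from compound 1 to compound 2 therefore cannot be read; the two ceilings are the limit of > 100000 nM in this assay, at which 1 of the 2 values shown sits, and (the limit of > 20000 nM in this assay, at which 1 of the 2 values shown sits). Compound 3 `Nc1c(C(=O)N2CCCCC2)sc2nc(-c3ccccc3)cc(C(F)(F)F)c12` differs from compound 2 by piperidin-1-yl in place of diethylamino on a carbonyl carbon. For the measured compounds named here, the only measured step, a step that the two limits leave unreadable from compound 1 to compound 2, has no readable size, so no measured step gives a direction for this change. With compound 2 at a limit in this assay, compound 3 is expected to stay near that ceiling, with no step beyond the scatter, and a limit rather than a number is the more likely report. The step of a number no higher from compound 2 to compound 3 (the limit leaves the size open) is expected to be small. Compound 3 is estimated at 100000 nM, between 30000 nM and 300000 nM.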

Compound 3, half-maximal cytotoxic concentration: > 20000 nM
Compound 3: a limit, no number; the forecaster's own chance of this, stated with the estimate: 75%; the middle value does not contradict the limit.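

In this assay compound 3 gives > 20000 nM, which is a limit and not a number. For the compounds shown here, compound 1, compound 2 and compound 3 all stand at limits, and no step among them can be read. The compounds shown leave open whether changing the group on the carbonyl carbon shifts tolerance in this assay at all.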